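Replacing Cyclopropyl with a Sulfonamide Arm on the Shared Core

The compounds below may be only part of what the source reports. "The series", "measured", "known", "first", "only" and "open" are said of these compounds alone.

Three compounds on the shared core have been measured in a functional assay on SW-620 cells (Homo sapiens) for antiproliferative activity, read by MTT assay, with a stated time of 72 h; a higher number here means a weaker inhibitor, a lower number a stronger inhibitor:

compound 1, `O=C1O[C@H]([C@@H](O)Cn2cc(CNS(=O)(=O)c3ccc(Cl)cc3F)nn2)C(OCc2ccccc2)=C1OCc1ccccc1`, gives 42400 nM
compound 2, `O=C1O[C@H]([C@@H](O)Cn2cc(CCO)nn2)C(OCc2ccccc2)=C1OCc1ccccc1`, gives only a limit of the assay, > 100000 nM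
compound 3, `O=C1O[C@H]([C@@H](O)Cn2cc(C3CC3)nn2)C(OCc2ccccc2)=C1OCc1ccccc1`, gives 54200 nM

Among the two numbers, compound 3 stands highest, yet its nearest neighbour is compound 1 and the gap between them lies within the scatter. The step of an at least 2.3-fold higher number from compound 1 to compound 2 (0.37 log units; beyond the scatter) shows the loss of the sulfonamide arm as a rise beyond the scatter, whereas an at least 1.8-fold lower number from compound 2 to compound 3 (0.26 log units; that floor lies within the scatter) is a fall whose floor lies within the scatter, a value that rests on (the limit of > 100000 nM in this assay, at which 1 of the 3 values shown sits).

Compound 4, `O=C1O[C@H]([C@@H](O)Cn2cc(CNS(=O)(=O)c3ccc(Cl)cc3)nn2)C(OCc2ccccc2)=C1OCc1ccccc1`, is not yet measured. It differs from compound 3 by (((4-chlorophenyl)sulfonyl)amino)methyl in place of cyclopropyl on an aromatic carbon. Since compound 4 thereby carries almost the same arm as compound 1, the two steps above point to a return toward the number of compound 1, and compound 4 is therefore expected to show a 1.4-fold lower number from compound 3 to compound 4 (0.13 log units; within the scatter) in this assay. On that basis compound 4 is estimated at 40000 nM, with a range from 15000 nM to 100000 nM.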

Compound 4, half-maximal inhibitory concentration: 18000 nM
The estimate for compound 4 lay 2.2-fold (0.35 log units) above the measured number; the range from low to high includes it.
By their numbers in this assay, from the lowest: compound 4; then compounds 1 and 3 (each within the scatter of the next). At a limit, above all of these: compound 2.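

In this assay, (((4-chlorophenyl)sulfonyl)amino)methyl in place of cyclopropyl on an aromatic carbon gives a 3.0-fold lower number from compound 3 to compound 4 (0.48 log units; beyond the scatter), so an arm at this position now separates from cyclopropyl beyond the scatter, whereas compound 1 and compound 3 stood within the scatter of each other. The arm's own aromatic ring also counts, as hydrogen in place of fluoro gives a 2.4-fold lower number from compound 1 to compound 4 (0.37 log units; beyond the scatter). The step of an at least 5.5-fold lower number from compound 2 to compound 4 (0.74 log units; beyond the scatter) is only a floor, set by a limit of the assay: the limit of > 100000 nM in this assay, at which 1 of the 4 values shown sits.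

The compounds shown leave open whether the sulfonyl link itself is needed, as an amide link in the arm would test. They also leave open whether chloro is the best group on that aromatic ring, or whether bromo or methoxy would serve as well.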